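The compounds below may be only part of what the source reports. "The series", "measured", "known", "first", "only" and "open" are said of these compounds alone.

Compound 1 `CCCCN(c1nc2ccccc2o1)[C@H](C)c1ccc(-c2ccccc2-c2nnn[nH]2)cc1` gives 44.3 ng.h/mL in an ADME assay on the whole organism (Macaca fascicularis) for pharmacokinetics, read by LC-MS, using cassette dosing, at a dose of 1 mg/kg by the oral route; on this read-out lower numbers stand for lower exposure and higher numbers for higher exposure at the dose given.
Compound 2 `CCCCN(c1nc2c(C(=O)NC)cccc2o1)[C@H](C)c1ccc(-c2ccccc2-c2nnn[nH]2)cc1` gives 25.7 ng.h/mL in this assay.
Compound 3 `CCCCN(c1nc2c(C(=O)O)cccc2o1)[C@H](C)c1ccc(-c2cc(Cl)ccc2-c2nc(=O)o[nH]2)cc1` gives 1040 ng.h/mL in this assay.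

Among the compounds with values here, on these numbers compound 1 sits between the other two: its gap to compound 2 is within the scatter, while compound 3 shows a far larger number but differs from compound 1 in several places, so no single step connects them. Compound 4 `CCCCN(c1nc2c(CO)cccc2o1)[C@H](C)c1ccc(-c2ccccc2-c2nnn[nH]2)cc1` differs from compound 1 by hydroxymethyl in place of hydrogen on an aromatic carbon. Within the data shown here, the only single step known at this place, a 1.7-fold lower number from compound 1 to compound 2 (0.24 log units; within the scatter), stayed within the scatter. A small group entering there is therefore expected to leave this assay essentially unchanged, and compound 4 is estimated at 35 ng.h/mL, ranging from 12 ng.h/mL to 100 ng.h/mL. This estimate means an expected step of a 1.3-fold lower number from compound 1 to compound 4 (0.10 log units; within the scatter).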

Compound 4, area under the concentration-time curve: 20 ng.h/mL
For compound 4 the middle estimate is 1.8-fold (0.24 log units) above the measured one; low and high end bracket the measured number.
By their numbers in this assay, from the lowest: compounds 4, 2 and 1 (each within the scatter of the next, the first and the last beyond it); then compound 3.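

Hydroxymethyl on this aromatic carbon gives the first step at this place that lies beyond the scatter in this assay, with a 2.2-fold lower number from compound 1 to compound 4 (0.35 log units; beyond the scatter), though the step is only modest. Swapping between the two groups tested here separates them by no more than the scatter, at a 1.3-fold lower number from compound 2 to compound 4 (0.11 log units; within the scatter), so hydroxymethyl and methylcarbamoyl cannot be told apart. Nothing available explains the step from hydrogen to hydroxymethyl.

Still open, on these data alone, is how an amine or a single fluorine atom on this carbon of the core of compound 1 would read.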